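The source may hold more compounds than are shown below. What is called first, only, known or untested is meant among the compounds shown, and "the series" means these compounds.

Measured so far in a physicochemical assay for solubility, read by HPLC, using the shake flask method, measured as kinetic solubility, with a stated time of 20 h, at pH 6.5, tested at 200 uM; on this read-out lower numbers stand for lower solubility and higher numbers for higher solubility:
Compound 1, `NS(=O)(=O)c1cncc(-c2ccc3nccc(-c4cn[nH]c4)c3n2)c1` — for compound 1 only a limit is known, < 5000 nM.
Compound 2, `CS(=O)(=O)c1cccc(-c2ccc3nccc(-c4ccncc4)c3n2)c1` — for compound 2 only a limit is known, < 5000 nM.
Compound 3, `CS(=O)(=O)c1cccc(-c2ccc3nccc(N4CCNCC4)c3n2)c1` — compound 3 gives 165000 nM.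

Compound 2 thus stands at the limit of < 5000 nM in this assay, at which 2 of the 3 values shown sit; no number, only that bound, is known for it. Compound 4, `C[C@@H](CO)NS(=O)(=O)c1cccc(-c2ccc3nccc(-c4ccncc4)c3n2)c1`, differs from compound 2 in one place: (1-(hydroxymethyl)ethyl)amino in place of methyl on a sulfonyl sulfur. Going by the values given here, the single measured step, an at least 33-fold higher number from compound 2 to compound 3 (1.51 log units; beyond the scatter), concerns another position and another group, so it bears on the present change only loosely; no measured step touches the sulfonyl sulfur whose other neighbours are aromatic carbon. For compound 4 the expected step is an at least 3.0-fold higher number from compound 2 to compound 4 (0.47 log units; beyond the scatter). The estimate for compound 4 is 15000 nM, between 3000 nM and 60000 nM, with a real chance that this assay again reports only a limit.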

Compound 4, solubility: 50000 nM
The estimate for compound 4 lay 3.3-fold (0.52 log units) below the measured number; low and high end bracket the measured number.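

In this assay the sulfonyl sulfur is a position that responds on its own: with pyridin-4-yl kept, (1-(hydroxymethyl)ethyl)amino in place of methyl gives an at least 10-fold higher number from compound 2 to compound 4 (1.00 log units; beyond the scatter) and a real number rather than a limit. Compound 2 carries only a limit, so this step has no upper bound: the limit of < 5000 nM in this assay, at which 2 of the 4 values shown sit.

Open, from the compounds shown here alone, is which part of the new group carries the step, the sulfonamide nitrogen or the hydroxyl; a plain amino group on the sulfur would separate the two. Also open, going by these compounds, is whether this change adds to piperazin-1-yl on the core.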